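From 4-methoxyphenyl to 4-methylphenyl

This account rests on a few compounds, and the source may have more. Where it says the series, first, only, none or still open, it means among the compounds named here.

Compound 1 `CC1OC2(C=CC(=O)C=C2)N(c2nc(-c3ccc4ccccc4c3)nn2-c2ccccc2)C1=O` – 310 nM
Compound 2 `COc1ccc(-n2nc(-c3ccc4ccccc4c3)nc2N2C(=O)C(C)OC23C=CC(=O)C=C3)cc1` – 860 nM

In a functional assay on A549 cells (Homo sapiens) for antiproliferative activity, with a stated time of 5 days (a lower number here means a stronger inhibitor, a higher number a weaker inhibitor), compound 2 has the higher of the two measured numbers, which makes it the weaker inhibitor of the pair. Compound 3 `Cc1ccc(-n2nc(-c3ccc4ccccc4c3)nc2N2C(=O)C(C)OC23C=CC(=O)C=C3)cc1` differs from it in one place: methyl in place of methoxy on an aromatic carbon, para to a large group. Among the compounds with values here, only one measured step bears on this place, the modest 2.8-fold higher number from compound 1 to compound 2 (0.44 log units; beyond the scatter), where methoxy replaced hydrogen. Within the data shown here, no measurement yet shows what methyl does here. Removing the methoxy may therefore recover part of that step, so a small move to a lower number is expected in this assay. The estimated step is a 1.7-fold lower number from compound 2 to compound 3 (0.24 log units; within the scatter). For compound 3 the expected value is 500 nM, with an estimated range of 220 nM to 1100 nM.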

Compound 3, half-maximal inhibitory concentration: 1210 nM
Estimate against measurement, compound 3: 2.4-fold (0.38 log units) below, and the stated range ends below it.
By their numbers in this assay, from the lowest: compound 1; then compounds 2 and 3 (each within the scatter of the next).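

Exchanging methoxy for methyl gives a 1.4-fold higher number from compound 2 to compound 3 (0.15 log units; within the scatter) in this assay, so these two groups cannot be told apart at this place, para to a large group. Removing the methoxy therefore does not by itself bring back the number seen with hydrogen: methyl gives a 3.9-fold higher number from compound 1 to compound 3 (0.59 log units; beyond the scatter), a step beyond the scatter, as is the one for methoxy, a 2.8-fold higher number from compound 1 to compound 2 (0.44 log units; beyond the scatter), and so both compounds with a group here stand apart from compound 1, which carries only hydrogen. The available data offer no explanation for this pattern.

With only hydrogen, methyl and methoxy shown here, it remains open how an amine, a carboxylic acid or a longer chain such as butyl would behave at this place. On these data alone, it is also open whether any group here could give a lower number than hydrogen does.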